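Alkylsulfanyl chain length on the shared nucleoside core

The compounds below may be only part of what the source reports. "The series", "measured", "known", "first", "only" and "open" are said of these compounds alone.

Measured so far:
- compound 1 `CSc1nc(NCc2ccc(C)cc2)c2ncn([C@@H]3O[C@H](CO)[C@@H](O)[C@H]3O)c2n1`: "not determined" (no result reported) in a functional assay on a cell-free system (Platelet, plasma, Homo sapiens) for inhibition, with stated times of 1 min and 3 min; on this read-out higher numbers stand for weaker inhibition and lower numbers for stronger inhibition
- compound 2 `CCCSc1nc(NCc2ccccc2)c2ncn([C@@H]3O[C@H](CO)[C@@H](O)[C@H]3O)c2n1`: 216000 nM
- compound 3 `CSc1nc(NCc2ccccc2)c2ncn([C@@H]3O[C@H](CO)[C@@H](O)[C@H]3O)c2n1`: "not determined" (no result reported) in this assay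

In this assay compound 3 gives "not determined" (no result reported). Compound 1, which carries a methyl on the benzyl group, likewise gives "not determined" (no result reported). Going by the values given here, compound 2, the propylsulfanyl member, is the only one with a number, and in this assay compound 2 gives 216000 nM. Among the compounds with values here, no step between measured compounds can be stated from these three entries, so where compound 3 stands on the numbers is simply open.

Compound 4 `CCCCSc1nc(NCc2ccccc2)c2ncn([C@@H]3O[C@H](CO)[C@@H](O)[C@H]3O)c2n1` is the next member. Its difference from compound 3: propyl in place of hydrogen on a saturated chain carbon bound to a sulfur. Read one bond further out, this is methyl to butyl, methylsulfanyl to butylsulfanyl. Since compound 3 has no value, no step size in this assay can be set for this change, and no direction is supported. Within the data shown here, the only anchor is compound 2 with its value in the weak range. For compound 4 a value near 150000 nM is expected in this assay, with a range from 30000 nM to 800000 nM.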

Compound 4, half-maximal inhibitory concentration: 202000 nM
Estimate against measurement, compound 4: 1.3-fold (0.13 log units) below; the range from low to high includes it.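

In this assay the propylsulfanyl and butylsulfanyl members can now be compared directly, and the comparison gives a 1.1-fold lower number from compound 2 to compound 4 (0.03 log units; within the scatter) for methyl in place of hydrogen on a saturated chain carbon, three bonds along the chain from a sulfur. The step from compound 3 to compound 4 cannot be read: compound 3 has no number. No measured evidence bears on this result.

As far as these compounds go, whether the methylsulfanyl members, compound 3 and compound 1, fall in the same weak range as the two longer chains stays open, as does any effect of the methyl on the benzyl group of compound 1. A longer chain such as hexylsulfanyl, or a chain carrying an amine, could show whether the numbers stay level beyond butylsulfanyl.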